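A few compounds are considered here, and "the series" means these few. Any claim that something is new, unique, unknown or untested is made for them only; others in the source may bear on it.

Of the compounds shown here, three sharing one core have been measured so far. In a toxicity assay on Hepa-1c1c7 cells (Mus musculus) for inhibition (a higher number here means a weaker inhibitor, a lower number a stronger inhibitor), compound 1 `CCCCCCCCCC(O)C#CC#CC(O)CCC`, which carries propyl, gives 30000 nM. Compound 2 `CCCCCCCCCC(O)C#CC#CC(O)CCCCC`, which carries pentyl, gives 12000 nM. Compound 3 `CCCCCCCCCC(O)C#CC#CC(O)C1CCCCC1`, which carries cyclohexyl, gives 44000 nM. That is the highest number of the three, but it lies within the scatter of compound 1 and clearly above compound 2 only.

The next compound, compound 4 `CCCCCCCCCC(O)C#CC#CC(O)CC(C)C`, is made from compound 3 by one change: isobutyl in place of cyclohexyl on a saturated chain carbon bound to an oxygen on a saturated carbon and a triple-bonded carbon. It puts isobutyl in place of cyclohexyl on a saturated chain carbon bound to an oxygen on a saturated carbon and a triple-bonded carbon. Isobutyl has no ring, so the nearest guides are the two ring-free compounds. Two measured steps lead into compound 3 at this same carbon: a 1.5-fold higher number from compound 1 to compound 3 (0.17 log units; within the scatter), and a 3.7-fold higher number from compound 2 to compound 3 (0.56 log units; beyond the scatter). The step between the two ring-free compounds is a 2.5-fold lower number from compound 1 to compound 2 (0.40 log units; beyond the scatter).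

With no branched chain yet measured, compound 4 is expected to fall between compound 1 at 30000 nM and compound 2 at 12000 nM. The expected step is therefore modest and downward, a 2.2-fold lower number from compound 3 to compound 4 (0.34 log units; beyond the scatter). For compound 4 the estimate in this assay is 20000 nM, with an expected range of 10000 nM to 40000 nM.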

Compound 4, half-maximal inhibitory concentration: > 50000 nM
Compound 4 ended at the assay's limit (the forecaster's own chance of this, stated with the estimate: 5%); middle value at least 2.5-fold (0.39 log units) away from the limit.
By their numbers in this assay, from the lowest: compound 2; then compounds 1 and 3 (each within the scatter of the next). At a limit, above all of these: compound 4.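

In this assay compound 4 gives > 50000 nM, which is a limit of the assay and not a number: the limit of > 50000 nM in this assay, at which 1 of the 4 values shown sits. Read against the other compounds, this yields an at least 4.1-fold higher number from compound 2 to compound 4 (0.61 log units; beyond the scatter), while the floors of an at least 1.6-fold higher number from compound 1 to compound 4 (0.22 log units; that floor lies within the scatter) and an at least 1.1-fold higher number from compound 3 to compound 4 (0.05 log units; that floor lies within the scatter) lie within the scatter. At this carbon, then, replacing the cyclohexyl ring with the ring-free isobutyl did not bring the number down toward that of compound 2, so the earlier drop from propyl to pentyl does not extend to this branched chain, and only compound 2 is clearly a stronger inhibitor than compound 4.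

The limit leaves open whether compound 4 lies close to compounds 1 and 3 or far beyond them, so no order among these three can be drawn from it. Also open, going by these compounds, is whether a longer straight chain such as heptyl would lower the number further than pentyl does, and what an amine or a carboxylic acid at the end of the chain on this carbon would do.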